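Cyclobutenedione series: butyl to tert-butyl on the imine nitrogen

The source may report more compounds than this note shows. Statements on the series, on what has been measured and on what is new or still open speak of the compounds shown alone.

Measured so far:
compound 1, `CCCC/N=c1\c(O)c(O)\c1=N/Cc1ccc(C#N)cc1`, > 30000 nM
compound 2, `CCc1cc(C#N)ccc1C/N=c1\c(O)c(O)\c1=N/C(C)(C)CC`, 110 nM
compound 3, `CCC(C)(C)/N=c1\c(O)c(O)\c1=N/Cc1c(C)cccc1Cl`, 4400 nM

Compound 1 carries a butyl group on the double-bonded nitrogen. In a functional assay for inhibition, with Rattus norvegicus as the target (on this read-out lower numbers stand for stronger inhibition and higher numbers for weaker inhibition), compound 1 returns only a limit, > 30000 nM, and no number; this is the limit described in the limit of > 30000 nM in this assay, at which 1 of the 3 values shown sits. Compound 2 gives a number in this assay, 110 nM. Compound 3 gives 4400 nM in this assay. Compound 1 therefore stands at the weak end of what is shown here, with the other two returning numbers below the limit.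

The step to be followed runs from compound 1 to compound 4, `CC(C)(C)/N=c1\c(O)c(O)\c1=N/Cc1ccc(C#N)cc1`. The change is tert-butyl in place of butyl on a double-bonded nitrogen; the two compounds have the same atoms, joined differently. Among the measured compounds shown here, no measured pair differs in one place, so the size of this step is not known from data; compounds 2 and 3 both carry a group other than a straight chain on that nitrogen and both return numbers, while compound 1 with butyl does not.

For compound 4 a gain is expected, estimated at 2000 nM, within 300 nM to 15000 nM, which would mean a step of an at least 15-fold lower number from compound 1 to compound 4 (1.17 log units; beyond the scatter).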

Compound 4, half-maximal inhibitory concentration: 270 nM
The estimate for compound 4 lay 7.4-fold (0.87 log units) above the measured number; measured number below the stated range.
By their numbers in this assay, from the lowest: compound 2; then compound 4; then compound 3. At a limit, above all of these: compound 1.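

Among the compounds shown here, with the rest of compound 1 unchanged, tert-butyl in place of butyl on a double-bonded nitrogen forms the first pair that differs in one place, and in this assay it shows an at least 110-fold lower number from compound 1 to compound 4 (2.04 log units; beyond the scatter). Butyl and tert-butyl match in everything counted for them, including heavy atoms, rings, hydrogen-bond donors and acceptors and net charge, so this step comes with a change in how the same atoms are joined and no change in those counts. Compound 1 gives > 30000 nM, which is a limit and not a number, and the step is a bound and not an exact size because of that limit: the limit of > 30000 nM in this assay, at which 1 of the 4 values shown sits.

Where an isopropyl or a cyclobutyl group on this nitrogen would fall remains open, as does the outcome with an amine or a carboxylic acid at the end of a chain in the same place. Also open, as far as these compounds go, is whether the exchange of butyl for tert-butyl gives a step of similar size when the nitrile-bearing group on the other nitrogen is replaced.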